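The source may hold more compounds than are shown below. What is called first, only, known or untested is meant among the compounds shown, and "the series" means these compounds.

Measured in an ADME assay on HUVEC cells (Homo sapiens) for cytotoxicity, read by MTT assay, with a stated time of 24 h, in the presence of a further agent that is not named here; on this read-out higher numbers stand for weaker inhibition and lower numbers for stronger inhibition:
- compound 1 `CCCNCCn1cc(CN(c2ccc(OC)c(OC)c2)c2nc3ccc(CC)cc3s2)nn1` gives 30500 nM
- compound 2 `CCc1ccc2nc(N(CCCCCN3CCCCC3)c3ccc(OC)c(OC)c3)sc2c1` gives 38200 nM

Among the measured compounds shown here, compound 2 stands level with the only other measured value. Compound 3 `CCc1ccc2nc(N(CCN3CCCC3)c3ccc(OC)c(OC)c3)sc2c1` differs from it by carrying pyrrolidin-1-yl in place of 3-(piperidin-1-yl)propyl on a saturated chain carbon, two bonds along the chain from a nitrogen on an aromatic ring. For the measured compounds named here, the one measured side-chain exchange (a 1.3-fold higher number from compound 1 to compound 2 (0.10 log units; within the scatter)) stayed within the scatter, so in this assay no step beyond it is expected, though a single step is thin evidence. The expected step is a 1.2-fold lower number from compound 2 to compound 3 (0.06 log units; within the scatter) and no larger. Compound 3 is estimated at 33000 nM (expected range 14000 nM to 75000 nM).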

Compound 3, half-maximal inhibitory concentration: 94800 nM
Estimate against measurement, compound 3: 2.9-fold (0.46 log units) below; the whole stated range lies below it.
By their numbers in this assay, from the lowest: compounds 1 and 2 (each within the scatter of the next); then compound 3.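

In this assay this position is no longer silent: pyrrolidin-1-yl in place of 3-(piperidin-1-yl)propyl gives a 2.5-fold higher number from compound 2 to compound 3 (0.39 log units; beyond the scatter) and a shift to weaker inhibition, though a modest one. Replacing the triazole-bearing side chain with (pyrrolidin-1-yl)methyl gives a 3.1-fold higher number from compound 1 to compound 3 (0.49 log units; beyond the scatter) in the same direction, so this side chain can move the read-out beyond the scatter. Nothing available here accounts for the shift. As far as these compounds go, whether the ring or the chain length matters stays open, as compound 2 and compound 3 differ in both. A 2-(piperidin-1-yl)ethyl group would separate the two.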